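The source may report more compounds than this note shows. Statements on the series, on what has been measured and on what is new or still open speak of the compounds shown alone.

Among the measured compounds shown here, compound 2 `CN(C)c1ccc2c(=O)c(C(=O)Nc3cc(F)cc(F)c3)cn(-c3ccc(OCCCCCCC[n+]4ccccc4)c(Cl)c3)c2n1` is the one compound here with a number attached: in an assay on LX2 cells for inhibition of COL1A1 promoter (Homo sapiens), read by a luciferase reporter, with a stated time of 24 h, tested at 50 uM (a higher number here means a stronger effect of the compound at the concentration tested, a lower number a weaker effect), compound 2 gives 21.4%. Compound 1 `CN(C)c1ccc2c(=O)c(C(=O)Nc3cc(F)cc(F)c3)cn(-c3ccc(OCCCCCCC[N+]4(C)CCCCC4)c(Cl)c3)c2n1` has an entry but no number, since in this assay compound 1 is reported as "not active" (no number reported). So compound 2 stands as the only measured point, with no second number to set it against. Compound 3 `CN(C)c1ccc2c(=O)c(C(=O)Nc3cc(F)cc(F)c3)cn(-c3ccc(OCCCCCCC[N+](C)(C)C4CCCCC4)c(Cl)c3)c2n1` is not yet measured. Compared with compound 2, compound 3 carries a group of 9 heavy atoms (8 carbon, 1 nitrogen; one six-membered non-aromatic ring of carbon only) in place of a group of 6 heavy atoms (5 carbon, 1 nitrogen; one six-membered aromatic ring with 1 hetero atom), on a saturated chain carbon, seven bonds along the chain from an oxygen on an aromatic ring. For the measured compounds named here, no measured pair shows what such a change does in this assay, so there is no step to lean on. The two entries so far both sit low or absent, which argues for a small change at most. The step from compound 2 to compound 3 is therefore expected to be a number 8.4 percentage points lower from compound 2 to compound 3 (within the scatter), within the scatter or slightly downward. For compound 3 the estimate in this assay is 13%, in a range from 0% to 30%.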

Compound 3, a percentage reported as inhibition, at one concentration (the size of the read-out at that concentration, not a potency): 86.2%
Compound 3: middle estimate off by 73.2 percentage points, on the low side; the measured number lies above the stated range.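

In this assay, the group on a saturated chain carbon, seven bonds along the chain from an oxygen on an aromatic ring, proves to matter greatly: replacing the six-membered aromatic ring with 1 hetero atom by the group with a six-membered non-aromatic ring of carbon only gives a number 64.8 percentage points higher from compound 2 to compound 3 (beyond the scatter) at this position. Both groups have a net charge of +1 and no hydrogen-bond donors or acceptors, so these listed features do not separate the two compounds. Nothing available here explains the difference.

Compound 1 also has a saturated six-membered ring at the chain end, yet compound 1 is reported as "not active" (no number reported), so having a saturated ring does not by itself account for the result. Going by these compounds, whether a trimethylammonium group or a shorter chain would keep this effect remains open.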